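Replacing the bromophenyl ring with thiophene in a cinnamide series

This account rests on a few compounds, and the source may have more. Where it says the series, first, only, none or still open, it means among the compounds named here.

Of the compounds shown here, three sharing one core have been measured in a functional assay on B16-F10 cells (Mus musculus) for inhibition, read by MTT assay, with a stated time of 48 h; on this read-out lower numbers stand for stronger inhibition and higher numbers for weaker inhibition. Compound 1 `O=C(/C=C/c1ccc(Br)cc1)Nc1ccc2ncnc(Nc3cccc(Br)c3)c2c1` gives 10.7 ug/mL. Compound 2 `Cc1ccc(/C=C/C(=O)Nc2ccc3ncnc(Nc4cccc(Br)c4)c3c2)cc1` gives 1.39 ug/mL. Compound 3 `O=C(/C=C/c1ccc(Br)cc1)Nc1ccc2ncnc(Nc3cccc(Cl)c3)c2c1` gives 0.75 ug/mL, the lowest of the three numbers, though its gap to compound 2 is within the scatter and only its gap to compound 1 stands beyond it.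

Compound 4 `O=C(/C=C/c1cccs1)Nc1ccc2ncnc(Nc3cccc(Cl)c3)c2c1` has not yet been measured. It differs from compound 3 in one place: thiophen-2-yl in place of 4-bromophenyl on a double-bonded chain carbon bound to a double-bonded chain carbon. Within the data shown here, no measured step swaps one ring for another, so there is no direct precedent. Among the measured compounds shown here, the step from compound 1 to compound 2, a 7.7-fold lower number from compound 1 to compound 2 (0.89 log units; beyond the scatter), is the only one touching the same ring, and it shows that a change there can move this assay by a modest amount; the step of a 14-fold lower number from compound 1 to compound 3 (1.15 log units; beyond the scatter) lies on the other side of the core. Given this, the estimate for compound 4 is a number close to that of compound 3, with wide uncertainty, around 1.5 ug/mL (range 0.4 ug/mL to 6 ug/mL), which would mean an expected step of a 2.0-fold higher number from compound 3 to compound 4 (0.30 log units; within the scatter).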

Compound 4, half-maximal inhibitory concentration: 4.26 ug/mL
Compound 4: middle estimate off by 2.8-fold (0.45 log units), on the low side, within the range that was stated.
By their numbers in this assay, from the lowest: compounds 3 and 2 (each within the scatter of the next); then compound 4; then compound 1.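

In this assay, the change of ring gives a 5.7-fold higher number from compound 3 to compound 4 (0.75 log units; beyond the scatter) and so weakens inhibition: thiophen-2-yl, a five-membered aromatic ring holding sulfur, does not stand in fully for 4-bromophenyl on this chain. The earlier step on this ring, a 7.7-fold lower number from compound 1 to compound 2 (0.89 log units; beyond the scatter) with methyl in place of bromo, changed only the group on the ring, whereas this result shows that exchanging the whole ring also moves the number beyond the scatter. No measurement given here explains why this ring exchange weakens inhibition.

From the compounds shown here alone, whether a plain phenyl, a pyridine or a furan ring on this chain would fall nearer compound 3 or compound 4 stays open. Also open, going by these compounds, is whether thiophen-2-yl would have the same effect with bromo on the other side of the core, as in compound 1.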